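The source may hold more compounds than are shown below. What is called first, only, known or untested is meant among the compounds shown, and "the series" means these compounds.

Compound 1, `CCCOC(=O)Nc1ccc([Se]C#N)cc1`, gives 19200 nM in an ADME assay on BEAS-2B cells (Homo sapiens) for cytotoxicity, read by MTT assay, with a stated time of 72 h; on this read-out higher numbers stand for weaker inhibition of growth and lower numbers for stronger inhibition of growth.
Compound 2, `C=CCOC(=O)Nc1ccc([Se]C#N)cc1`, gives 21400 nM in this assay.

For the measured compounds named here, compound 2 carries the larger of the two numbers measured so far, but its only neighbour, compound 1, lies so close that the pair cannot be told apart: the step of a 1.1-fold higher number from compound 1 to compound 2 (0.05 log units; within the scatter) is within the scatter. Compound 3, `CCCCCCOC(=O)Nc1ccc([Se]C#N)cc1`, has not been measured. It differs from compound 2 by pentyl in place of vinyl on a saturated chain carbon bound to an oxygen next to a carbonyl group. Going by the values given here, the single measured step, a 1.1-fold higher number from compound 1 to compound 2 (0.05 log units; within the scatter), exchanged groups at that same place and left the number essentially unchanged, so there is no measured step that directly shows what a pentyl chain does here. The expected step is therefore a 1.8-fold lower number from compound 2 to compound 3 (0.25 log units; within the scatter), a modest move toward a lower number, with wide uncertainty. Compound 3 is estimated at 12000 nM in this assay, within a range from 5000 nM to 30000 nM.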

Compound 3, concentration for 50% growth inhibition: 2800 nM
Compound 3: middle estimate off by 4.3-fold (0.63 log units), on the high side; the measured number lies below the stated range.
By their numbers in this assay, from the lowest: compound 3; then compounds 1 and 2 (each within the scatter of the next).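

Compound 1 and compound 2 could not be told apart, so the exchange between them gave no sign that this place matters. In this assay, pentyl in place of vinyl gives a 7.6-fold lower number from compound 2 to compound 3 (0.88 log units; beyond the scatter) and propyl in place of hydrogen gives a 6.9-fold lower number from compound 1 to compound 3 (0.84 log units; beyond the scatter) on the same chain. The group on a saturated chain carbon bound to an oxygen next to a carbonyl group can therefore shift this number toward stronger inhibition of growth, and no available measurement explains why.

Hexyl is the longest chain shown, so it remains open whether an octyl or decyl chain would lower the number further or reverse the trend. From the compounds shown here alone, it is also open whether a cyclohexyl ring or a chain ending in an amine would do the same as hexyl.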